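This account rests on a few compounds, and the source may have more. Where it says the series, first, only, none or still open, it means among the compounds named here.

Measured in an ADME assay on MT4 cells (Homo sapiens) for cytotoxicity, read by MTT assay; on this read-out lower numbers stand for higher toxicity in this test and higher numbers for lower toxicity in this test:
- compound 1 `Cc1cc(C)cc(S(=O)(=O)c2c(C(=O)Nc3ccc(O)cc3)[nH]c3ccc(Cl)cc23)c1`: 18100 nM
- compound 2 `Cc1cc(C)cc(S(=O)(=O)c2c(C(=O)NC(C)c3ccccc3O)[nH]c3ccc(Cl)cc23)c1`: 21800 nM
- compound 3 `Cc1cc(C)cc(S(=O)(=O)c2c(C(=O)NCc3ccc(O)c(O)c3)[nH]c3ccc(Cl)cc23)c1`: 18300 nM

These three compounds share a core and differ only in the group on the amide-type nitrogen. Compound 2, at 21800 nM, stands level with the other two, as its values lie within the usual scatter of both.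

The next compound to be tested is compound 4 `Cc1cc(C)cc(S(=O)(=O)c2c(C(=O)NC(C)C(=O)NCc3cccc(O)c3)[nH]c3ccc(Cl)cc23)c1`. It carries (3-hydroxybenzyl)carbamoyl in place of 2-hydroxyphenyl on a saturated chain carbon bound to an amide-type nitrogen and a saturated chain carbon.

The closest evidence comes from the three steps among the measured compounds. These are a 1.2-fold higher number from compound 1 to compound 2 (0.08 log units; within the scatter), a 1.0-fold higher number from compound 1 to compound 3 (0.00 log units; within the scatter) and a 1.2-fold lower number from compound 2 to compound 3 (0.08 log units; within the scatter). Each swapped one group on the amide-type nitrogen for another, and none moved the number beyond the scatter. Among the measured compounds shown here, no measured compound carries the entering group, so these steps are only a loose guide and the range must stay wide.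

In this assay, no change beyond the scatter is therefore expected, in either direction. The expected step is a 1.1-fold higher number from compound 2 to compound 4 (0.04 log units; within the scatter). The estimated value for compound 4 is 24000 nM, with an expected range of 10000 nM to 70000 nM.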

Compound 4, half-maximal cytotoxic concentration: 23800 nM
For compound 4 the middle estimate is 1.0-fold (0.00 log units) above the measured one; measured number inside the range.
By their numbers in this assay, from the lowest: compounds 1, 3, 2 and 4 (each within the scatter of the next).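

In this assay the swap of 2-hydroxyphenyl for (3-hydroxybenzyl)carbamoyl gives a 1.1-fold higher number from compound 2 to compound 4 (0.04 log units; within the scatter) and so stays within the scatter. The earlier steps shown here exchanged whole groups directly on the amide-type nitrogen, whereas this one acts one carbon further along, on a saturated chain carbon bound to an amide-type nitrogen and a saturated chain carbon, and it brings a larger group of 11 heavy atoms in place of 7, with 2 hydrogen-bond donors and 2 acceptors in place of 1 of each; for this one pair, then, the cytotoxicity read-out does not respond to added size or to an extra amide link at this position. Nothing available here explains why the number holds steady.

From the compounds shown here alone, all four compounds carry groups with no net charge and a hydroxyl-bearing benzene ring, so it remains open whether an amine or a carboxylic acid in place of (3-hydroxybenzyl)carbamoyl would also leave the number unmoved. The same question stands for a longer chain at this position and for any change to the shared core, which stays the same throughout.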